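This account rests on a few compounds, and the source may have more. Where it says the series, first, only, none or still open, it means among the compounds named here.

For the measured compounds named here, compound 1 `COc1cc(Cc2nc3c(N)ncnc3n2CCCC(C)C)cc(OC)c1OC` is one of two compounds measured in a functional assay on MCF7 cells (Homo sapiens) for antiproliferative activity; a lower number here means a stronger inhibitor, a higher number a weaker inhibitor. In this assay compound 1 gives 69200 nM, the highest of the two numbers. Its companion, compound 2 `CC[C@H](C)Cn1c(Cc2cc(OC)c(OC)c(OC)c2)nc2c(N)nc(F)nc21`, gives 43700 nM in this assay; the two numbers lie within the scatter of each other, so neither compound can be set above the other. Both are weak inhibitors of cell growth.

Compound 3 `C=CCCn1c(Cc2cc(OC)c(OC)c(OC)c2)nc2c(N)ncnc21` has not yet been measured in this assay. It differs from compound 1 in one place: vinyl in place of isobutyl on a saturated chain carbon, two bonds along the chain from an aromatic nitrogen. The chain on the ring nitrogen thus becomes shorter and carries a double bond. Going by the values given here, no measured pair shows what such a change does here, so there is nothing to set a direction. The expectation for compound 3 is therefore a step of a 1.3-fold lower number from compound 1 to compound 3 (0.10 log units; within the scatter) that stays near compound 1, with no shift beyond the scatter firmly expected in either direction. On that basis, compound 3 is estimated to give 55000 nM in this assay, with a range from 15000 nM to 200000 nM.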

Compound 3, half-maximal inhibitory concentration: 40700 nM
For compound 3 the middle estimate is 1.4-fold (0.13 log units) above the measured one, and the stated range covers the measured number.
By their numbers in this assay, from the lowest: compounds 3, 2 and 1 (each within the scatter of the next).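

In this assay, vinyl in place of isobutyl on a saturated chain carbon, two bonds along the chain from an aromatic nitrogen, gives a 1.7-fold lower number from compound 1 to compound 3 (0.23 log units; within the scatter). This is the first pair shown that differs in one place, and it shows that this particular change of the chain end, which makes the chain shorter and adds a double bond, leaves the number within the scatter, so the isobutyl end of compound 1 is not needed to keep the activity at this weak level. No other measurement here bears on this result, so the pair says what the change does to the number and nothing about how it does so.

One step within the scatter cannot show whether any group at this position would move the number beyond the scatter, as a chain ending in an amine or a carboxylic acid, or a longer chain, might or might not do. It also leaves open whether the same change would give a similar result on the core of compound 2, which carries a fluorine that compound 1 lacks.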